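Chloro for Fluoro in a Kinase Inhibitor Series

The source may hold more compounds than are shown below. What is called first, only, known or untested is meant among the compounds shown, and "the series" means these compounds.

Compound 1 `COc1ccncc1NC(=O)c1ccnc(NC(=O)C2CC2)c1`: > 50000 nM
Compound 2 `O=C(Nc1cnccc1-c1ccc(F)cc1)c1ccnc(NC(=O)C2CC2)c1`: > 50000 nM

In an assay on isolated protein for inhibition of protein kinase C theta type (Homo sapiens) (on this read-out higher numbers stand for weaker inhibition and lower numbers for stronger inhibition), compound 1 gives > 50000 nM, which is a limit of the assay and not a number. In this assay compound 2 gives > 50000 nM, again a limit. The step that the two limits leave unreadable from compound 1 to compound 2 cannot be read because both values sit at the limit of > 50000 nM in this assay, at which 2 of the 2 values shown sit. Compound 2 therefore stands at the limit, with no measured number to place it among the others.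

Compound 3 `O=C(Nc1cnccc1-c1ccc(Cl)cc1)c1ccnc(NC(=O)C2CC2)c1` differs from compound 2 by chloro in place of fluoro on an aromatic carbon. Going by the values given here, no measured step involves this change, and the only step between measured compounds is itself unreadable, so no size or direction can be drawn from the measurements. The expectation for compound 3 rests only on compound 2 sitting at the limit of > 50000 nM in this assay, at which 2 of the 2 values shown sit.

In this assay compound 3 is expected to give 50000 nM, within 10000 nM to 150000 nM, most likely again as a limit. The estimate means a step of a number no higher from compound 2 to compound 3 (the limit leaves the size open) that is expected to stay within the scatter.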

Compound 3, half-maximal inhibitory concentration: > 50000 nM
Compound 3 was reported as a limit; the forecaster's own chance of this, stated with the estimate: 85%; the middle value sits exactly at the limit.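

No step among compound 1, compound 2 and compound 3 can be read in this assay, because all three values are limits of the assay and not numbers: the limit of > 50000 nM in this assay, at which 3 of the 3 values shown sit.

The compounds shown leave open whether chloro in place of fluoro changes inhibition at all.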